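Carbamate to oxadiazole amide on the shared core

A few compounds are considered here, and "the series" means these few. Any claim that something is new, unique, unknown or untested is made for them only; others in the source may bear on it.

Measured compounds:
- compound 1, `Cc1nc(S(C)(=O)=O)ccc1Oc1ncnc(OC2CCN(C(=O)OC(C)C)CC2)c1F`: 21 nM
- compound 2, `CCC1(OC(=O)N2CCC(Oc3ncnc(Oc4ccc(S(C)(=O)=O)nc4C)c3F)CC2)CC1`: 22 nM
- compound 3, `Cc1nc(S(C)(=O)=O)ccc1Oc1ncnc(OC2CCN(C(=O)C3(C)CC3)CC2)c1F`: 761 nM

In a functional assay on isolated protein for inhibition of Glucose-dependent insulinotropic receptor (Homo sapiens), read by HTRF and cAMP accumulation (on this read-out higher numbers stand for an effect only at larger amounts of compound and lower numbers for an effect already at smaller amounts), compound 2 gives 22 nM, the second highest of the three numbers; it sits within the scatter of compound 1, as a 1.0-fold higher number from compound 1 to compound 2 (0.02 log units; within the scatter) shows, and far from compound 3, as a 35-fold higher number from compound 2 to compound 3 (1.54 log units; beyond the scatter) shows. Compound 4, `Cc1nc(S(C)(=O)=O)ccc1Oc1ncnc(OC2CCN(C(=O)c3nc(C(C)(C)F)no3)CC2)c1F`, is not yet measured. It differs from compound 2 in one place: a group of 9 heavy atoms (5 carbon, 2 nitrogen, 1 oxygen, 1 fluorine; one five-membered aromatic ring with 3 hetero atoms) in place of a group of 6 heavy atoms (5 carbon, 1 oxygen; one three-membered non-aromatic ring of carbon only), on a carbonyl carbon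

Among the measured compounds shown here, two measured steps bear on this change. Both replace the oxygen-bearing group on the carbonyl carbon with a carbon-only group, and both are large: a 36-fold higher number from compound 1 to compound 3 (1.56 log units; beyond the scatter) and a 35-fold higher number from compound 2 to compound 3 (1.54 log units; beyond the scatter). The group entering compound 4 is larger and carries more hydrogen-bond acceptors than the group entering compound 3, so the outcome is uncertain, but a rise of the number beyond the scatter is expected, smaller than seen for compound 3. The expected step is a 3.6-fold higher number from compound 2 to compound 4 (0.56 log units; beyond the scatter). Compound 4 is therefore estimated at 80 nM, within 12 nM to 600 nM.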

Compound 4, half-maximal effective concentration: 43.4 nM
Compound 4: the middle estimate sits 1.8-fold (0.27 log units) above what was measured, and the stated range covers the measured number.
By their numbers in this assay, from the lowest: compounds 1, 2 and 4 (each within the scatter of the next, the first and the last beyond it); then compound 3.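

The earlier compounds shown here tied a carbon-only group on this carbonyl carbon, the 1-methylcyclopropyl of compound 3, to a large step up in this assay, so the oxygen of the carbamates could have seemed essential. Compound 4 shows that it is not: a group with a five-membered aromatic ring with 3 hetero atoms also sits on this carbonyl carbon without that oxygen, and an 18-fold lower number from compound 3 to compound 4 (1.24 log units; beyond the scatter) recovers most of the difference. It stays close to the carbamates, with a 2.0-fold higher number from compound 2 to compound 4 (0.30 log units; within the scatter) and only a modest gap in a 2.1-fold higher number from compound 1 to compound 4 (0.32 log units; beyond the scatter).

Nothing measured here explains why this group and the 1-methylcyclopropyl group differ so much. The compounds shown leave open what the fluorine in the entering group contributes, and how an amine or a longer chain on this carbonyl carbon would compare.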